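Swapping the Ring at the Chain End of Compound 1

The compounds below may be only part of what the source reports. "The series", "measured", "known", "first", "only" and "open" are said of these compounds alone.

Compound 1 `COc1cc2c(Oc3ccc(NC(=O)c4cn(-c5ccccc5)nn4)cc3F)ccnc2cc1OCCCN1CCCC1`: 180 nM
Compound 2 `COc1cc2c(Oc3ccc(NC(=O)c4cn(-c5ccccc5Cl)nn4)cc3F)ccnc2cc1OCCCN1CCCC1`: 150 nM
Compound 3 `COc1cc2c(Oc3ccc(NC(=O)c4cn(-c5ccccc5C)nn4)cc3F)ccnc2cc1OCCCN1CCCC1`: 1200 nM

In a functional assay on HT-29 cells (Homo sapiens) for cytotoxicity, read by MTT assay, with a stated time of 72 h (a lower number here means a stronger inhibitor, a higher number a weaker inhibitor), compound 1 gives 180 nM, the second highest of the three numbers. Its nearest neighbour is compound 2, where a 1.2-fold lower number from compound 1 to compound 2 (0.08 log units; within the scatter) keeps the two within the scatter. Its furthest is compound 3, where a 6.7-fold higher number from compound 1 to compound 3 (0.82 log units; beyond the scatter) moves the number modestly upward, and an 8.0-fold higher number from compound 2 to compound 3 (0.90 log units; beyond the scatter) shows the same kind of shift from compound 2. All three measured compounds share the same core and differ only in what sits on the aromatic ring attached to the triazole.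

The unmeasured compound 4 `COc1cc2c(Oc3ccc(NC(=O)c4cn(-c5ccccc5)nn4)cc3F)ccnc2cc1OCCCN1CCC(C)CC1` changes a different part of the molecule: 4-methylpiperidin-1-yl in place of pyrrolidin-1-yl on a saturated chain carbon, three bonds along the chain from an oxygen on an aromatic ring. Within the data shown here, none of the measured steps touches this chain end, so there is no measured step that bears directly on the change. With no evidence either way, the expectation is that the number stays close to that of compound 1, and the step of a 1.1-fold higher number from compound 1 to compound 4 (0.05 log units; within the scatter) is estimated to lie within the scatter. For compound 4 in this assay the estimate is 200 nM, with a range from 80 nM to 500 nM.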

Compound 4, half-maximal inhibitory concentration: 190 nM
Beside the measured number, compound 4's estimate is 1.1-fold (0.02 log units) above it, and the stated range covers the measured number.
By their numbers in this assay, from the lowest: compounds 2, 1 and 4 (each within the scatter of the next); then compound 3.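

The earlier steps shown here all changed a substituent on an aromatic carbon, and there this assay could respond strongly (a 6.7-fold higher number from compound 1 to compound 3 (0.82 log units; beyond the scatter)). Among these compounds, the new step is the first to touch the saturated chain, three bonds along from an oxygen on an aromatic ring. Here a six-membered ring carrying a methyl, 4-methylpiperidin-1-yl, takes the place of the five-membered pyrrolidin-1-yl, and the two compounds cannot be told apart (a 1.1-fold higher number from compound 1 to compound 4 (0.02 log units; within the scatter)), so this particular exchange at this position leaves the cell reading as it was, unlike the methyl step on the aromatic carbon. Nothing shown here speaks to why the two rings read alike in this assay.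

This is a single exchange, so the compounds shown leave open whether the chain end would accept a ring with a second hetero atom, such as morpholine or piperazine, an open-chain dimethylamine, or a carboxylic acid in place of the amine. They also leave open whether 4-methylpiperidin-1-yl would read the same way on the chloro or methyl compounds, or with a longer chain between the oxygen and the ring.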